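Chain-replacement step on the shared core toward compound 3

A few compounds are considered here, and "the series" means these few. Any claim that something is new, unique, unknown or untested is made for them only; others in the source may bear on it.

Measured compounds:
- compound 1, `c1ccc2c(c1)CN[C@@H](CN(CCCCNCC1CCCCC1)[C@H]1CCCc3cccnc31)C2`: > 30000 nM
- compound 2, `CC(C)(CN)CCN(C[C@H]1Cc2ccccc2CN1)[C@H]1CCCc2cccnc21`: > 30000 nM

In a functional assay on cells for agonist activity at C-X-C chemokine receptor type 4 (Homo sapiens), read by fluorescence and calcium flux, with a stated time of 90 s (a lower number here means that less compound is needed, a higher number that more compound is needed for the effect), compound 1 reaches only a limit of the assay, > 30000 nM. In this assay compound 2 likewise reaches only a limit, > 30000 nM. Going by the values given here, compound 2 therefore has no number of its own to stand on; the single measured step, a step that the two limits leave unreadable from compound 1 to compound 2, cannot be read because the limit of > 30000 nM in this assay, at which 2 of the 2 values shown sit, holds both ends of it.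

Compound 3, `C(=C/CN(C[C@H]1Cc2ccccc2CN1)[C@H]1CCCc2cccnc21)\CNC1CCOCC1`, differs from compound 2 in one place: 3-((oxan-4-yl)amino)prop-1-en-1-yl in place of 2-(aminomethyl)-2-methylpropyl on a saturated chain carbon bound to an amine nitrogen. The chain that enters carries an amine bearing a six-membered saturated ring with one hetero atom, and a double bond in the chain, where compound 2 had a short branched chain with a primary amine.

Among the compounds with values here, no measured step is readable for this kind of change. Compound 1, which also carried a longer amine-bearing chain on the same core, sat at the limit, and compound 2 sits at the limit, so the expectation for compound 3 is anchored only by the limit of > 30000 nM in this assay, at which 2 of the 2 values shown sit. Compound 3 is expected to give 30000 nM (range 6000 nM to 100000 nM), which amounts to an expected step of a number no higher from compound 2 to compound 3 (the limit leaves the size open) and most probably again a limit rather than a number.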

Compound 3, half-maximal effective concentration: > 30000 nM
Compound 3: only a limit was reported; the forecaster's own chance of this, stated with the estimate: 70%; the middle value sits exactly at the limit.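

In this assay compound 3 gives > 30000 nM as a limit and not a number. No new step can be read from compound 1 or compound 2 to compound 3, because each pair ends at the same limit: the limit of > 30000 nM in this assay, at which 3 of the 3 values shown sit. From the compounds shown here alone, whether any chain on the shared core gives a numerical value in this assay stays open, and with it any ranking of the three chains.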